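The source may hold more compounds than are shown below. What is called first, only, known or untested is meant among the compounds shown, and "the series" means these compounds.

Compound 1 `Fc1ccccc1N1CCN(Cn2nc(-c3ccc4c(c3)OCCO4)oc2=S)CC1` bears a 2-fluorophenyl on the amine nitrogen in the ring of the shared core. In a functional assay on SW 1116 cells (Homo sapiens) for antiproliferative activity, read by MTT assay, with a stated time of 48 h (a lower number here means a stronger inhibitor, a higher number a weaker inhibitor), compound 1 gives 37800 nM, the higher of the two numbers recorded. Compound 2 `COc1ccccc1N1CCN(Cn2nc(-c3ccc4c(c3)OCCO4)oc2=S)CC1` gives 16900 nM in this assay, so that a 2.2-fold lower number from compound 1 to compound 2 (0.35 log units; beyond the scatter). Compound 3 `COc1cccc(N2CCN(Cn3nc(-c4ccc5c(c4)OCCO5)oc3=S)CC2)c1` reaches only a limit of > 50000 nM in this assay. Between compound 2 and compound 3, an at least 2.9-fold higher number from compound 2 to compound 3 (0.47 log units; beyond the scatter), while an at least 1.3-fold higher number from compound 1 to compound 3 (0.12 log units; that floor lies within the scatter).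

Compound 4 `S=c1oc(-c2ccc3c(c2)OCCO3)nn1CN1CCN(c2ccccc2Cl)CC1` differs from compound 1 by chloro in place of fluoro on an aromatic carbon. Among the compounds with values here, no measured step exchanges one halogen for another; the only step at the same place, a 2.2-fold lower number from compound 1 to compound 2 (0.35 log units; beyond the scatter), swapped the halogen for methoxy and gave a modest gain. A halogen-for-halogen exchange is therefore expected to move the number little, possibly slightly lower. Compound 4 is expected to give about 30000 nM in this assay, with a likely range from 12000 nM to 60000 nM. That estimate means a 1.3-fold lower number from compound 1 to compound 4 (0.10 log units; within the scatter), a step expected to stay within the usual scatter.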

Compound 4, half-maximal inhibitory concentration: > 50000 nM
Compound 4 ended at the assay's limit (the forecaster's own chance of this, stated with the estimate: 20%); middle value at least 1.6-fold (0.22 log units) away from the limit.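

The exchange of fluoro for chloro on this aromatic carbon, ortho to a large group, gives an at least 1.3-fold higher number from compound 1 to compound 4 (0.12 log units; that floor lies within the scatter), so the two halogens cannot be told apart here. The exchange of methoxy for chloro at the same place gives an at least 2.9-fold higher number from compound 2 to compound 4 (0.47 log units; beyond the scatter), which shows that the gain seen with compound 2 does not extend to chloro and leaves compound 2 as the strongest of the four compounds. Compound 3 and compound 4 both sit at a limit, so the step between them cannot be read: the limit of > 50000 nM in this assay, at which 2 of the 4 values shown sit.

Where compound 4 truly lies beyond its limit remains open, and with it whether chloro is really weaker than fluoro. As far as these compounds go, it is also open whether a bromo, a methyl or an ethoxy on this carbon would follow methoxy or the halogens.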